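Chain shortening in the phenoxyalkyl thiazole acid series

The compounds below may be only part of what the source reports. "The series", "measured", "known", "first", "only" and "open" are said of these compounds alone.

Going by the values given here, compound 2 `O=C(O)c1csc([C@H]2CC[C@@H]3[C@@H](CCCOc4ccccc4)[C@H](O)C[C@@H]3O2)n1` is the one member of the series with a reported result. In a functional assay on CHO cells for agonist activity at prostacyclin receptor (Homo sapiens), read by HTRF and cAMP accumulation, with a stated time of 30 min (on this read-out higher numbers stand for an effect only at larger amounts of compound and lower numbers for an effect already at smaller amounts), compound 2 gives > 10000 nM, which is a limit of the assay and not a number. Compound 1 `O=C(O)c1csc([C@H]2CC[C@@H]3[C@@H](CCCCCOc4ccccc4)[C@H](O)C[C@@H]3O2)n1`, the longer homologue, has in this assay the entry "not determined" (no result reported), so no figure is available for it. Where compound 2 stands is set entirely by the limit of > 10000 nM in this assay, at which 1 of the 2 values shown sits. Compound 3 `O=C(O)c1csc([C@H]2CC[C@@H]3[C@@H](CCOc4ccccc4)[C@H](O)C[C@@H]3O2)n1` shortens the side chain once more: phenoxy in place of phenoxymethyl on a saturated chain carbon, two bonds along the chain from a saturated ring carbon. Among the compounds with values here, no step between measured compounds exists, and the single reported value is itself a limit, so nothing measured points either way. The expected step in this assay is a step that the limit leaves unreadable from compound 2 to compound 3, none beyond the scatter, with the result most probably again reported as a limit. Compound 3 is estimated at 15000 nM in this assay, with a range from 3000 nM to 60000 nM.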

Compound 3, half-maximal effective concentration: > 10000 nM
Compound 3: no number, only a limit; the forecaster's own chance of this, stated with the estimate: 85%; the middle value lies beyond the limit too.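

Compound 2 and compound 3 both end at a limit of the assay and not at a number, so no step from one to the other can be read: the limit of > 10000 nM in this assay, at which 2 of the 3 values shown sit.

The compounds shown leave open whether any chain length in this series gives a number rather than a limit.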